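Working notes on the step from compound 3 to compound 4

A few compounds are considered here, and "the series" means these few. Any claim that something is new, unique, unknown or untested is made for them only; others in the source may bear on it.

Measured compounds in an assay on isolated protein for inhibition of protein kinase C zeta type (Homo sapiens), read by mobility shift assay, tested at 30 uM; a lower number here means less inhibition, a higher number more inhibition at the concentration tested (going by the name of the read-out):
- compound 1 `Cc1cc2c(c(N)nn2C)c(N2CC[C@H](O)C2)n1`: 19%
- compound 2 `COCCNc1nc(C)cc2c1c(N)nn2C`: -10%
- compound 3 `Cc1cc2c(cn1)c(N)nn2C`: -59%

Compound 3 stands lowest of the three numbers in this assay. Its nearest neighbour is compound 2, and the step of a number 49 percentage points lower from compound 2 to compound 3 (beyond the scatter) is beyond the scatter; the step of a number 78 percentage points lower from compound 1 to compound 3 (beyond the scatter) is larger still. Both of these steps, like a number 29 percentage points lower from compound 1 to compound 2 (beyond the scatter), concern the substituent on an aromatic carbon of the shared core, which is hydrogen in compound 3.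

Compound 4 `Cc1cc2[nH]nc(N)c2cn1` is not yet measured. It differs from compound 3 by hydrogen in place of methyl on an aromatic nitrogen. The change sits on an aromatic nitrogen of the five-membered ring, not on the aromatic carbon that the three measured steps address, so none of those steps bears on it directly; the three measured compounds all carry the methyl on that nitrogen, and nothing here tells what its removal does. Given this, no step beyond the scatter is expected in this assay, and the estimate for compound 4 is simply placed near compound 3 with a wide range: for compound 4 the expected value is -50%, between -90% and 0%, which means an expected step of a number 9 percentage points higher from compound 3 to compound 4 (within the scatter).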

Compound 4, a percentage reported as inhibition, at one concentration (the size of the read-out at that concentration, not a potency): -275%
The estimate for compound 4 lay 225 percentage points above the measured number, outside the stated range (below it).
By their numbers in this assay, from the lowest: compound 4; then compound 3; then compound 2; then compound 1.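

In this assay, the methyl on the aromatic nitrogen of the five-membered ring proves to be far from a silent feature: a number 216 percentage points lower from compound 3 to compound 4 (beyond the scatter), a step larger than any seen at the aromatic carbon, including a number 78 percentage points lower from compound 1 to compound 3 (beyond the scatter). Among these compounds, the earlier compounds all carried this methyl, so they gave no reading at this position; this is the first, and compound 4, at -275%, now stands lowest of the four numbers. Among the compounds shown here, nothing measured here accounts for the size or direction of this step, or for a number so far below zero.

As far as these compounds go, it remains open how an ethyl group, or a longer chain ending in an amine, on that same nitrogen would read in this assay, and so whether the number follows the size of the group at all. Also open, from the compounds shown here alone, is whether hydrogen in place of methyl gives a step of similar size when the aromatic carbon carries 3-hydroxypyrrolidin-1-yl, as in compound 1, or (2-methoxyethyl)amino, as in compound 2.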